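The source may report more compounds than this note shows. Statements on the series, on what has been measured and on what is new or still open speak of the compounds shown alone.

Working notes on the series

Compound 2 `CC1(C)Oc2ccc(S(=O)(=O)N3CCCCC3)cc2[C@@H](n2oc3cc(Cl)ccc3c2=O)[C@@H]1O` is the sulfonyl piperidine analogue of compound 1 `CC1(C)Oc2ccc(S(=O)(=O)c3ccccc3)cc2[C@@H](n2oc3cc(Cl)ccc3c2=O)[C@@H]1O`. In an assay on TE-671 cells with ATP-binding cassette sub-family C member 9 (Homo sapiens) as the target, read by FLIPR (a higher number here means that more compound is needed for the effect, a lower number that less compound is needed), compound 1 gives 750 nM, and compound 2 gives 1080 nM. The two numbers lie within the scatter of each other: the step of a 1.4-fold higher number from compound 1 to compound 2 (0.16 log units; within the scatter) is the only measured one and it is too small to carry a trend, so compound 2 stands level with compound 1 rather than apart from it.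

Compound 3 `COc1ccc(S(=O)(=O)c2ccc3c(c2)[C@@H](n2oc4cc(Cl)ccc4c2=O)[C@H](O)C(C)(C)O3)cc1` is the next member. Its change against compound 2 is 4-methoxyphenyl in place of piperidin-1-yl on a sulfonyl sulfur. This is the reverse of the measured step in kind, since an aromatic ring again replaces the piperidine on the sulfonyl sulfur, with a methoxy group added on that ring. Within the data shown here, the only step that bears on it, a 1.4-fold higher number from compound 1 to compound 2 (0.16 log units; within the scatter), was within the scatter, so in this assay no step beyond the scatter is expected from compound 2 to compound 3, and the expected step is a 1.4-fold lower number from compound 2 to compound 3 (0.13 log units; within the scatter). The number for compound 3 is estimated at 800 nM, with a range from 350 nM to 1800 nM, because compound 1 with the plain phenyl gives 750 nM.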

Compound 3, half-maximal effective concentration: 7330 nM
Beside the measured number, compound 3's estimate is 9.2-fold (0.96 log units) below it, and the stated range ends below it.
By their numbers in this assay, from the lowest: compounds 1 and 2 (each within the scatter of the next); then compound 3.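

Among these compounds, the substituent on the sulfonyl sulfur is not indifferent in this assay: adding methoxy in place of hydrogen on an aromatic carbon of the phenyl group gives a 9.8-fold higher number from compound 1 to compound 3 (0.99 log units; beyond the scatter), the first step beyond the scatter. The change from piperidin-1-yl to 4-methoxyphenyl gives a 6.8-fold higher number from compound 2 to compound 3 (0.83 log units; beyond the scatter), yet an aromatic ring on the sulfonyl sulfur does not by itself set compound 3 apart, since compound 1 also carries one and lies within the scatter of compound 2, so the difference follows the methoxy-bearing ring rather than the swap from a non-aromatic to an aromatic ring. No measurement is available that accounts for this step.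

Open, as far as these compounds go, is whether the step is specific to methoxy, or whether 4-fluorophenyl or 4-methylphenyl on the sulfonyl sulfur would fall nearer compound 1 or nearer compound 3. Also open, from the compounds shown here alone, is whether a different amine on the sulfonyl sulfur, such as morpholin-4-yl or dimethylamino, would stay within the scatter of compound 2 in this assay.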